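The source may report more compounds than this note shows. Statements on the series, on what has been measured and on what is new or still open speak of the compounds shown alone.

Three compounds have been measured in a functional assay on MCF7 cells (Homo sapiens) for inhibition, read by MTT assay, with a stated time of 48 h; on this read-out lower numbers stand for stronger inhibition of growth and higher numbers for weaker inhibition of growth:

compound 1, `Cn1cc(C2CC(c3ccc(Br)cc3)=NN2C(=O)c2cccnc2)c2cc(Br)ccc21`, gives 11800 nM;
compound 2, `COc1ccc(C2=NN(C(=O)c3cccnc3)C(c3cn(C)c4ccc(Br)cc34)C2)cc1`, gives 1560 nM;
compound 3, `COc1ccc2c(c1)c(C1CC(c3ccc(Br)cc3)=NN1C(=O)c1ccc(OC)nc1)cn2C`, gives 6960 nM.

Compound 1 and compound 2 share a core and differ in one place: methoxy in place of bromo on an aromatic carbon. Among the measured compounds shown here, that single exchange brought a 7.6-fold lower number from compound 1 to compound 2 (0.88 log units; beyond the scatter), the only step of its kind seen so far, and it lies beyond the scatter of the method. Compound 3 is built on a core that differs from the core of compound 1 in more than one place; the difference between the two cores is not broken down here. Their values alone show that compound 3 and compound 1 lie within the scatter of each other.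

Compound 4, `COc1ccc(C2=NN(C(=O)c3ccc(OC)nc3)C(c3cn(C)c4ccc(OC)cc34)C2)cc1`, has not yet been measured. It stands to compound 3 as compound 2 stands to compound 1: methoxy in place of bromo on an aromatic carbon. The place of the exchange is described in the same words for both pairs, so it is the same change, made on a different core. Compound 4 is expected to show, in this assay, a step of a 5.4-fold lower number from compound 3 to compound 4 (0.73 log units; beyond the scatter). That expectation is somewhat smaller than the earlier step because a 7.6-fold lower number from compound 1 to compound 2 (0.88 log units; beyond the scatter) is known from one pair only, on a core that compound 3 does not share. The estimate for compound 4 is 1300 nM, with a range from 450 nM to 4000 nM.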

Compound 4, concentration for 50% growth inhibition: 560 nM
Beside the measured number, compound 4's estimate is 2.3-fold (0.37 log units) above it; low and high end bracket the measured number.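

Exchanging bromo for methoxy, which turns a 4-bromophenyl into a 4-methoxyphenyl, gave in this assay a 12-fold lower number from compound 3 to compound 4 (1.09 log units; beyond the scatter), so the growth-inhibiting effect grew stronger on this second core as well. The change therefore carried over from one core to the other, both in direction and, as far as the method can tell, in size: the same change on two cores in this assay, a 7.6-fold lower number (0.88 log units; beyond the scatter) from compound 1 to compound 2 and a 12-fold lower number (1.09 log units; beyond the scatter) from compound 3 to compound 4, 1.6-fold (0.22 log units) apart, within the scatter of two such steps What this does not show is why the change has this effect, and two pairs are too few to make it a rule for every core in the series; nor can the gap between the two steps be read as a real difference, so the second core cannot be said to respond more strongly than the first.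

The compounds shown leave open how other groups in the same place, para to a large group, would compare with bromo and methoxy, for example an amine, a carboxylic acid or a longer chain such as ethoxy. They also leave open whether the exchange would work in the same way on a third core, or on cells other than the ones used here.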